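The compounds below may be only part of what the source reports. "The series", "measured", "known", "first", "only" and "open" are said of these compounds alone.

Values from a functional assay for inhibition, with Homo sapiens as the target; on this read-out higher numbers stand for weaker inhibition and lower numbers for stronger inhibition:

- Compound 1 `Cc1ccc(Nc2nccc(-c3ccccn3)n2)cc1C`: 5900 nM
- Compound 2 `c1ccc(-c2ccnc(Nc3cccc(OCCn4ccnc4)c3)n2)nc1`: 400 nM

Of these two numbers, compound 2 has the lower, at 400 nM, and so shows the stronger inhibition. Compound 1 stands at 5900 nM, and this gap lies beyond the usual scatter of repeated measurements.

Compound 3 `Cc1cccc(Nc2nccc(-c3ccccn3)n2)c1` has not yet been measured. Compared with compound 2, it has this structural difference: methyl in place of 2-(1H-imidazol-1-yl)ethoxy on an aromatic carbon. In words, methyl replaces 2-(1H-imidazol-1-yl)ethoxy on an aromatic carbon of a six-membered aromatic ring of carbon only, meta to a large group.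

For the measured compounds named here, no measured pair of compounds differs in just one place, so there is no direct measure of this change. The best guide is compound 1, which also carries methyl and lacks 2-(1H-imidazol-1-yl)ethoxy, and gives 5900 nM. A rise in this assay, meaning weaker inhibition, is therefore expected, and it should go beyond the scatter. The expected change is a 13-fold higher number from compound 2 to compound 3 (1.10 log units; beyond the scatter). For compound 3 the estimate is 5000 nM, with an expected range of 1500 nM to 17000 nM.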

Compound 3, half-maximal inhibitory concentration: 700 nM
For compound 3 the middle estimate is 7.1-fold (0.85 log units) above the measured one, outside the stated range (below it).
By their numbers in this assay, from the lowest: compounds 2 and 3 (each within the scatter of the next); then compound 1.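

In this assay the exchange of 2-(1H-imidazol-1-yl)ethoxy for methyl gives a 1.8-fold higher number from compound 2 to compound 3 (0.24 log units; within the scatter) and so, on this aromatic carbon, meta to a large group, a single carbon does as well as the group of 8 heavy atoms with its five-membered aromatic ring. The extra methyl of compound 1 counts for more, since hydrogen in place of that methyl gives an 8.4-fold lower number from compound 1 to compound 3 (0.93 log units; beyond the scatter) and thus a step beyond the scatter, whereas the much larger exchange stays within it. Nothing at hand explains why either change has the size it has.

The compounds shown leave open whether an amine or a carboxylic acid at the place of the methyl of compound 3 would keep this level of inhibition, and whether a plain ethoxy group, without the imidazole ring, would match methyl or the full chain. They also leave open what hydrogen alone would give at that place, so the methyl of compound 3 has no direct comparison of its own.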